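A Chlorophenyl Swap on a Nitroimidazole Dithiocarbamate

The source may report more compounds than this note shows. Statements on the series, on what has been measured and on what is new or still open speak of the compounds shown alone.

compound 1 `Cc1ncc([N+](=O)[O-])n1CC(O)CSC(=S)N1CCN(c2cccc(Cl)c2)CC1`: 1080000 nM
compound 2 `Cc1nc([N+](=O)[O-])cn1CC(O)CSC(=S)N1CCN(c2ccccc2)CC1`: > 5000000 nM
compound 3 `COc1ccccc1N1CCN(C(=S)SCC(O)Cn2cc([N+](=O)[O-])nc2C)CC1`: > 5000000 nM

In a toxicity assay on HeLa cells (Homo sapiens) for cytotoxicity, read by MTT assay, with a stated time of 24 h (a higher number here means a weaker inhibitor, a lower number a stronger inhibitor), compound 1 gives 1080000 nM. For compound 2 the read-out is only a limit, > 5000000 nM. For compound 3 the read-out is likewise only a limit, > 5000000 nM. Compound 3 thus stands at the limit of > 5000000 nM in this assay, at which 2 of the 3 values shown sit, with no number to rank it. Among the compounds with values here, the single measured step, a step that the two limits leave unreadable from compound 2 to compound 3, cannot be sized because both ends are limits. Compound 4 `Cc1nc([N+](=O)[O-])cn1CC(O)CSC(=S)N1CCN(c2cccc(Cl)c2)CC1` arises from compound 3 by 3-chlorophenyl in place of 2-methoxyphenyl on an amine nitrogen in a ring. Within the data shown here, no measured step bears on this change; compound 1, which also carries a 3-chlorophenyl on an amine nitrogen in a ring, gives 1080000 nM. The step of an at least 1.6-fold lower number from compound 3 to compound 4 (0.22 log units; that floor lies within the scatter) is therefore expected to be small and uncertain. Compound 4 is expected near 3000000 nM, within 800000 nM to 10000000 nM.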

Compound 4, half-maximal inhibitory concentration: 1740000 nM
The estimate for compound 4 lay 1.7-fold (0.24 log units) above the measured number; the measured number falls inside the stated range.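

In this assay, a chlorine on the phenyl ring brings a readable number: chloro in place of hydrogen gives an at least 2.8-fold lower number from compound 2 to compound 4 (0.45 log units; beyond the scatter), and 3-chlorophenyl in place of 2-methoxyphenyl gives an at least 2.8-fold lower number from compound 3 to compound 4 (0.45 log units; beyond the scatter). Both steps start from a limit and not from a number: the limit of > 5000000 nM in this assay, at which 2 of the 4 values shown sit. Exchanging the 2-methyl-5-nitro-1H-imidazol-1-yl for the 2-methyl-4-nitro-1H-imidazol-1-yl gives a 1.6-fold higher number from compound 1 to compound 4 (0.21 log units; within the scatter), which leaves compound 1 and compound 4 indistinguishable.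

As far as these compounds go, how far the number depends on chlorine itself stays open. So does what a 2-chlorophenyl, a 3-fluorophenyl or a 3-methylphenyl would give on the same amine nitrogen.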